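This account rests on a few compounds, and the source may have more. Where it says the series, first, only, none or still open, it means among the compounds named here.

The three compounds measured so far, with their results in a functional assay on C8166 cells (Homo sapiens) for cytotoxicity, read by MTT assay, with a stated time of 72 h; on this read-out lower numbers stand for higher toxicity in this test and higher numbers for lower toxicity in this test:

compound 1 `Cc1ccc(S(=O)(=O)N2CC3(C[C@H]2C(=O)N/N=C/c2ccccc2[N+](=O)[O-])SCCS3)cc1`: 65000 nM
compound 2 `COc1ccc(/C=N/NC(=O)Cn2c(=O)c(C)nc3ccccc32)cc1OC`: > 526000 nM
compound 3 `Cc1ccc(S(=O)(=O)N2CC3(C[C@H]2C(=O)NN)SCCS3)cc1`: > 519000 nM

Compound 1 is the only one of the three that gives a number. For compound 2 the result of > 526000 nM is a limit of this assay, not a number; compound 2 therefore stands at the limit of > 526000 nM in this assay, at which 1 of the 3 values shown sits. Compound 3 likewise sits at the limit of > 519000 nM in this assay, at which 1 of the 3 values shown sits.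

Among the measured compounds shown here, the single measured step, an at least 7.9-fold higher number from compound 1 to compound 3 (0.90 log units; beyond the scatter), concerns a change of a quite different kind, in which the whole aromatic hydrazone end is cut away; it says nothing about small additions to an aromatic ring. Compound 4 `COc1cc(/C=N/NC(=O)Cn2c(=O)c(C)nc3ccccc32)cc(OC)c1OC` differs from compound 2 only in methoxy in place of hydrogen on an aromatic carbon. For the measured compounds named here, no measured step bears on such a change, so there is no ground to expect a step in this assay beyond the scatter in either direction; compound 2 already sits at the limit, and compound 4 is expected to do the same.

The step from compound 2 to compound 4 is therefore estimated as a step that the limit leaves unreadable from compound 2 to compound 4. For compound 4 the expected result in this assay is 600000 nM, within a range of 200000 nM to 2000000 nM.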

Compound 4, half-maximal cytotoxic concentration: > 487000 nM
Compound 4 gave a limit, no number (the forecaster's own chance of this, stated with the estimate: 80%); the middle value is on the limit's open side.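

In this assay compound 4 gives > 487000 nM, which is a limit and not a number. Compound 2 also stands at a limit, so the step between compound 2 and compound 4 cannot be read. The compounds shown leave open whether methoxy in place of hydrogen on an aromatic carbon changes the half-maximal cytotoxic concentration at all.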